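The source may report more compounds than this note shows. Statements on the series, on what has been measured and on what is new or still open speak of the compounds shown alone.

Measured compounds:

Compound 1, `COc1ncc(-c2cc(OC)c3nc(N)nc(C)c3c2)cc1NS(=O)(=O)c1ccc(F)cc1F`, gives 280 nM in a functional assay on NCI-H460 cells (Homo sapiens) for cytotoxicity, read by MTT assay, with a stated time of 96 h; on this read-out higher numbers stand for weaker inhibition and lower numbers for stronger inhibition.
Compound 2, `COc1ncc(-c2cc(OC(C)C)c3nc(N)nc(C)c3c2)cc1NS(=O)(=O)c1ccc(F)cc1F`, gives 140 nM.
Compound 3, `COc1ncc(-c2cc(OC3CCCCC3)c3nc(N)nc(C)c3c2)cc1NS(=O)(=O)c1ccc(F)cc1F`, gives 96 nM.

On these three numbers compound 1 stands highest, meaning the weakest inhibition of the set. Compound 4, `COc1ncc(-c2cc(OC3CCC(F)(F)CC3)c3nc(N)nc(C)c3c2)cc1NS(=O)(=O)c1ccc(F)cc1F`, differs from compound 1 in one place: 4,4-difluorocyclohexyl in place of methyl on an oxygen on an aromatic ring. Two measured steps start from compound 1 and change the same methyl: a 2.0-fold lower number from compound 1 to compound 2 (0.30 log units; within the scatter), and a 2.9-fold lower number from compound 1 to compound 3 (0.46 log units; beyond the scatter). The further step between those two, a 1.5-fold lower number from compound 2 to compound 3 (0.16 log units; within the scatter), shows that the size of the ring-shaped group matters little once it is larger than methyl. Since 4,4-difluorocyclohexyl most resembles cyclohexyl, compound 4 is expected to sit near compound 3, so a modest lowering is expected, a 2.5-fold lower number from compound 1 to compound 4 (0.41 log units; beyond the scatter), giving an estimated 110 nM for compound 4, with a range of 50 nM to 250 nM.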

Compound 4, half-maximal inhibitory concentration: 83 nM
Estimate against measurement, compound 4: 1.3-fold (0.12 log units) above; low and high end bracket the measured number.
By their numbers in this assay, from the lowest: compounds 4, 3, 2 and 1 (each within the scatter of the next, the first and the last beyond it).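

In this assay, putting two fluorines on the cyclohexyl ring shows no clear effect, with a 1.2-fold lower number from compound 3 to compound 4 (0.06 log units; within the scatter), and the change from isopropyl is also small, with a 1.7-fold lower number from compound 2 to compound 4 (0.23 log units; within the scatter). Measured against methyl, however, 4,4-difluorocyclohexyl gives a step beyond the scatter, a 3.4-fold lower number from compound 1 to compound 4 (0.53 log units; beyond the scatter), so this oxygen carries the fluorinated ring as well as the plain one. Nothing available here explains these numbers. Still open, going by these compounds, is how this position would respond to an amine, such as a piperidine ring, or to a longer straight chain, such as butyl.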